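A few compounds are considered here, and "the series" means these few. Any claim that something is new, unique, unknown or untested is made for them only; others in the source may bear on it.

Measured so far:
compound 1 `Clc1cncc(N2CCCNCCC2)c1` — 103%
compound 2 `Brc1ccc(N2CCCNCCC2)cn1` — 139%

Two members of the series have been read in an assay on HEK293 cells with Neuronal acetylcholine receptor; alpha4/beta2 (Homo sapiens) as the target, read by FLIPR and calcium flux; a higher number here means a larger maximal response, a lower number a smaller maximal response. Compound 1 `Clc1cncc(N2CCCNCCC2)c1` gives 103% there, and compound 2 `Brc1ccc(N2CCCNCCC2)cn1` gives 139%. Of these two numbers compound 2 stands highest; the nearest is compound 1, whose number lies lower by a gap beyond the usual scatter.

The next compound, compound 3 `c1cncc(N2CCCNCCC2)c1`, differs from compound 2 in a single place: hydrogen in place of bromo on an aromatic carbon. Among the compounds with values here, no measured pair shows this same change, so the size of the step has no direct anchor. Within the data shown here, the only other halogenated member, compound 1, carries chloro and sits well below compound 2.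

The step of a number 31 percentage points lower from compound 2 to compound 3 (beyond the scatter) is expected to be a fall beyond the scatter, because compound 1 sits at 103%. Compound 3 is estimated at 108%, with a range from 80% to 138%.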

Compound 3, largest response reached (reported as efficacy), in percent of the reference or control that the assay uses: 78%
Compound 3: middle estimate off by 30 percentage points, on the high side; measured number outside the range, below it.
By their numbers in this assay, from the lowest: compound 3; then compound 1; then compound 2.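

In this assay, hydrogen in place of bromo on the aromatic carbon next to the ring nitrogen gives a number 61 percentage points lower from compound 2 to compound 3 (beyond the scatter), a large step, so the response is sensitive to what occupies this position. Hydrogen in place of chloro gives a number 25 percentage points lower from compound 1 to compound 3 (beyond the scatter), a modest step, and compound 3, without a halogen, therefore reads lowest of the three. No measurement in hand accounts for either step.

Compound 1 and compound 2 differ in more than one place, so these steps cannot separate the identity of the halogen from where it sits. From the compounds shown here alone, whether an amine, a methoxy group or a nitrile at the bromo position would keep the number near that of compound 2 remains open.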